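Phenyl in Place of Methyl on the Aromatic Oxygen

The source may report more compounds than this note shows. Statements on the series, on what has been measured and on what is new or still open speak of the compounds shown alone.

Of the compounds shown here, two have so far been measured in an assay on isolated protein for positive allosteric modulation of muscarinic acetylcholine receptor M5 (Homo sapiens); a higher number here means a larger maximal response, a lower number a smaller maximal response. Compound 1 `COc1ccc(CN2C(=O)C(=O)c3cc(OC(F)(F)F)ccc32)cc1` gives 91%, the higher of the two numbers. Compound 2 `O=C1C(=O)N(Cc2ccc(Br)cc2)c2ccccc21` gives 74%, which stands a step below compound 1 that is beyond the scatter. Compound 1 and compound 2 differ in more than one place, so their two values alone do not show what any single change does.

Compound 3 `O=C1C(=O)N(Cc2ccc(Oc3ccccc3)cc2)c2ccc(OC(F)(F)F)cc21` has not yet been measured. It differs from compound 1 in one place: phenyl in place of methyl on an oxygen on an aromatic ring. Going by the values given here, no step between measured compounds shows what this change does in this assay. With the rest of compound 1 kept, a large maximal response close to that of compound 1 is expected, with a step of a number 5 percentage points lower from compound 1 to compound 3 (within the scatter) that need not reach beyond the scatter. Compound 3 is therefore estimated at 86%, with a range from 62% to 110%.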

Compound 3, largest response reached (Emax), in percent of the reference or control that the assay uses: 75%
Beside the measured number, compound 3's estimate is 11 percentage points above it, within the range that was stated.
By their numbers in this assay, from the lowest: compounds 2 and 3 (each within the scatter of the next); then compound 1.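

Going by these compounds alone, this is the first comparison in the set that isolates a single change: in this assay, phenyl in place of methyl on an oxygen on an aromatic ring gives a number 16 percentage points lower from compound 1 to compound 3 (beyond the scatter). The position therefore accepts a six-carbon aromatic ring where a single carbon stood, and compound 3 still gives 75%, though the response does not stay at the level of compound 1. No measurement at hand accounts for this drop.

A single step cannot show whether the loss grows gradually as the group on the oxygen gets larger or is particular to phenyl. On these data alone, it also remains open how an ethyl or a cyclopropyl on the same oxygen, or an amine in place of that oxygen, would compare with compound 1 and compound 3.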